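The source may hold more compounds than are shown below. What is called first, only, known or untested is meant among the compounds shown, and "the series" means these compounds.

Measured compounds:
compound 1, `COc1c(Cl)cc(-c2ccc(C(=O)c3c(Cl)ccc(O)c3F)s2)cc1Cl`: 15 nM
compound 2, `Cc1cc(-c2ccc(C(=O)c3cc(F)c(F)c(O)c3C)s2)cc(C)c1O`: 159 nM
compound 3, `COc1c(Cl)cc(-c2ccc(C(=O)c3c(F)ccc(O)c3Cl)s2)cc1Cl`: 9.5 nM

These three values come from an assay on microsomes from placenta for inhibition of 17-beta-hydroxysteroid dehydrogenase type 2 (Homo sapiens), read by HPLC, in the presence of a further agent that is not named here; on this read-out lower numbers stand for stronger inhibition and higher numbers for weaker inhibition. Compound 1 holds the second highest of the three numbers; its nearest neighbour is compound 3, whose number lies within the scatter of it, while compound 2 sits furthest away with a number beyond the scatter.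

Compound 4, `O=C(c1ccc(-c2cc(Cl)c(O)c(Cl)c2)s1)c1c(Cl)ccc(O)c1F`, differs from compound 1 in one place: hydrogen in place of methyl on an oxygen on an aromatic ring. Going by the values given here, no measured pair shows this change on its own, so its effect is not known from the data. Without such a comparison, the step of a 1.3-fold higher number from compound 1 to compound 4 (0.12 log units; within the scatter) is expected to be small, in neither direction clearly beyond the scatter. On that basis compound 4 is expected to give 20 nM, with a plausible range from 5 nM to 80 nM.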

Compound 4, half-maximal inhibitory concentration: 18 nM
Compound 4: middle estimate off by 1.1-fold (0.05 log units), on the high side; the range from low to high includes it.
By their numbers in this assay, from the lowest: compounds 3, 1 and 4 (each within the scatter of the next); then compound 2.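

In this assay, putting hydrogen in place of methyl on this oxygen gives a 1.2-fold higher number from compound 1 to compound 4 (0.08 log units; within the scatter) and so leaves no readable difference between methoxy and hydroxy here. Going by these compounds alone, this is the first comparison in the set that isolates a single place, and it holds only for the core of compound 1. Nothing available explains why the two compounds read alike. As far as these compounds go, whether an ethoxy group, an amine or a carboxylic acid would be tolerated on this aromatic ring remains open. From the compounds shown here alone, it is also open whether the same change would read alike on the other side of the core.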